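Shortening the linker chain in a thiourea series

The source may report more compounds than this note shows. Statements on the series, on what has been measured and on what is new or still open speak of the compounds shown alone.

In a functional assay on the whole organism (stomach) with Rattus norvegicus as the target (a higher number here means that more compound is needed for the effect, a lower number that less compound is needed), compound 3 `CC/N=C(\S)NCCCCn1nc(-c2ccccc2)ccc1=O` gives 37.2 mg/kg and holds the lowest of the two numbers measured. Compound 1 `CC/N=C(/NC#N)NCCCn1nc(-c2ccccc2)ccc1=O` gives 78.3 mg/kg in this assay, a 2.1-fold lower number from compound 1 to compound 3 (0.32 log units; beyond the scatter). Compound 2 `CC/N=C(\S)NCCCn1nc(-c2ccccc2)ccc1=O` returns only a limit of the assay, > 100 mg/kg, rather than a number (the limit of > 100 mg/kg in this assay, at which 1 of the 3 values shown sits). The step from compound 2 to compound 3 was an at least 2.6-fold lower number from compound 2 to compound 3 (0.42 log units; beyond the scatter), while the step from compound 1 to compound 2 was an at least 1.2-fold higher number from compound 1 to compound 2 (0.10 log units; that floor lies within the scatter).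

Compound 4 `C/N=C(\S)NCCCn1nc(-c2ccccc2)ccc1=O` is not yet measured. Its change from compound 3 is a group of 5 heavy atoms (2 carbon, 2 nitrogen, 1 sulfur; no ring) in place of a group of 7 heavy atoms (4 carbon, 2 nitrogen, 1 sulfur; no ring), on a saturated chain carbon, three bonds along the chain from an aromatic nitrogen. This brings back the shorter chain linker seen in compound 2, combined with a smaller terminal group. Since compound 2 with that shorter linker reached only a limit, the step from compound 3 to compound 4 is expected to go up by about a 2.7-fold higher number from compound 3 to compound 4 (0.43 log units; beyond the scatter). Compound 4 is therefore estimated at 100 mg/kg, with a range from 40 mg/kg to 300 mg/kg, and a limit rather than a number is quite possible.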

Compound 4, dose for half-maximal effect: > 100 mg/kg
Compound 4 ended at the assay's limit; the forecaster's own chance of this, stated with the estimate: 50%; the middle value lies on the limit itself.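

In this assay compound 4 returns only a limit of the assay, > 100 mg/kg, rather than a number. Exchanging the group of 7 heavy atoms for the group of 5 heavy atoms, on a saturated chain carbon, three bonds along the chain from an aromatic nitrogen, gives an at least 2.6-fold higher number from compound 3 to compound 4 (0.42 log units; beyond the scatter), while the comparison with the nitrile-bearing compound gives only an at least 1.2-fold higher number from compound 1 to compound 4 (0.10 log units; that floor lies within the scatter), so that second floor shows no clear change. The step between compound 2 and compound 4 cannot be read because both stop at the limit: the limit of > 100 mg/kg in this assay, at which 2 of the 4 values shown sit.

The compounds shown do not separate the shorter chain from the swap of ethyl for methyl as the source of the rise from compound 3 to compound 4. They also leave open whether a chain longer than that of compound 3 would lower the number further.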